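A methyl in place of hydrogen on compound 1

This account rests on a few compounds, and the source may have more. Where it says the series, first, only, none or still open, it means among the compounds named here.

Compound 1 `C#CCNC1CCc2c(NCc3ccccc3)cccc21` gives > 20000 nM in an assay on cells for inhibition of Amine oxidase [flavin-containing] B (Homo sapiens), read by fluorescence and Amplex Red, with stated times of 30 min and 15 min (a higher number here means a weaker inhibitor, a lower number a stronger inhibitor), which is a limit of the assay rather than a number (the limit of > 20000 nM in this assay, at which 1 of the 2 values shown sits). Its fluoro analogue compound 2 `C#CCNC1CCc2c(NCc3cccc(F)c3)cccc21` gives 1860 nM in this assay, and the step of an at least 10-fold lower number from compound 1 to compound 2 (1.03 log units; beyond the scatter) shows that a single substituent on that aromatic carbon can move the read-out strongly. Compound 3 `C#CCNC1CCc2c(NCc3ccc(C)cc3)cccc21` differs from compound 1 by methyl in place of hydrogen on an aromatic carbon. Among the measured compounds shown here, only that one measured step bears on it, and it concerns fluoro rather than methyl, so a move toward a lower number is expected for compound 3, with wide uncertainty, an at least 2.5-fold lower number from compound 1 to compound 3 (0.39 log units; beyond the scatter). Compound 3 is estimated at 8000 nM, between 2000 nM and 30000 nM.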

Compound 3, half-maximal inhibitory concentration: 250 nM
For compound 3 the middle estimate is 32-fold (1.51 log units) above the measured one, and the stated range ends above it.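

The added methyl, on an aromatic carbon para to a large group, gives an at least 80-fold lower number from compound 1 to compound 3 (1.90 log units; beyond the scatter), so a single carbon at this place is enough to produce a clear reading in this assay. Compound 1 stands at a limit of the assay, not at a number: the limit of > 20000 nM in this assay, at which 1 of the 3 values shown sits. The methyl analogue also improves on the fluoro analogue, with a 7.4-fold lower number from compound 2 to compound 3 (0.87 log units; beyond the scatter), though that step changes both the group and its place. As far as these compounds go, it remains open whether the gain belongs to methyl or to the place, which 3-methylphenyl and 4-fluorophenyl would separate, and whether chloro or methoxy would serve equally well here.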